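A few compounds are considered here, and "the series" means these few. Any claim that something is new, unique, unknown or untested is made for them only; others in the source may bear on it.

In a functional assay on K562 cells (Homo sapiens) for inhibition, read by trypan blue exclusion, with a stated time of 72 h (a higher number here means a weaker inhibitor, a lower number a stronger inhibitor), compound 3 (`Cn1c(=O)c(S(=O)(=O)c2ccc(Cl)cc2)cc2cnc(Nc3cccc4[nH]ccc34)nc21`) gives 5000 nM, level with compound 2 (`COc1ccc(S(=O)(=O)c2cc3cnc(Nc4cccc5[nH]ccc45)nc3n(C)c2=O)cc1`) at 5000 nM. Compound 1 (`Cn1c(=O)c(S(=O)(=O)c2ccc(F)cc2)cc2cnc(Nc3ccc4cc[nH]c4c3)nc21`) gives 10000 nM, and its gap to compound 3 stays within the scatter, so the three values do not separate.

Compound 4 (`Cn1c(=O)c(S(=O)(=O)c2ccc(F)cc2)cc2cnc(Nc3cccc4[nH]ccc34)nc21`) follows from compound 3 by one exchange: fluoro in place of chloro on an aromatic carbon, para to a large group, or 4-chlorophenyl to 4-fluorophenyl (fluoro in place of chloro on an aromatic carbon).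

Among the compounds with values here, the only measured step at this place is no change at the digits printed from compound 2 to compound 3 (within the scatter), with chloro in place of methoxy on an aromatic carbon. It shows no movement in this assay. Compound 1 already carries the (4-fluorophenyl)sulfonyl group and gives 10000 nM, but it differs from compound 4 elsewhere in the structure, so it offers only loose support. No direct exchange of chloro for fluoro has been measured in this series.

On this limited evidence, no shift beyond the scatter is expected in this assay, and neither direction is favoured. The expected step is no change at the digits printed from compound 3 to compound 4 (within the scatter). For compound 4 the estimated value is 5000 nM, with an expected range of 2500 nM to 10000 nM.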

Compound 4, half-maximal inhibitory concentration: 750 nM
Compound 4: middle estimate off by 6.7-fold (0.82 log units), on the high side, and the stated range ends above it.
By their numbers in this assay, from the lowest: compound 4; then compounds 2, 3 and 1 (each within the scatter of the next).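

In this assay this aromatic carbon, para to a large group, is not indifferent to its substituent: a 6.7-fold lower number from compound 3 to compound 4 (0.82 log units; beyond the scatter) and a 6.7-fold lower number from compound 2 to compound 4 (0.82 log units; beyond the scatter) while no change at the digits printed from compound 2 to compound 3 (within the scatter) so fluoro separates from chloro and methoxy, which stay level with each other. Within the data shown here, the attachment point on the indole also counts, since with the (4-fluorophenyl)sulfonyl group held constant a 13-fold lower number from compound 1 to compound 4 (1.12 log units; beyond the scatter) and 1H-indol-4-yl in place of 1H-indol-6-yl is the only change in that step, so the weak figure of compound 1 says nothing against fluoro at the sulfonyl-bearing ring. Nothing in hand accounts for either step.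

From the compounds shown here alone, whether the gain belongs to fluoro alone or extends to other groups at this place, such as hydrogen, bromo, nitrile or trifluoromethyl, remains open. Also open, going by these compounds, is how far the 1H-indol-4-yl group can be changed, for instance by a methyl on the indole nitrogen or by an amine on its ring, with the 4-fluorophenyl group kept.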